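A few compounds are considered here, and "the series" means these few. Any claim that something is new, unique, unknown or untested is made for them only; others in the source may bear on it.

Working notes on the series. Compound 1 `CCOC(=O)c1sc(-c2ccccn2)nc1N1CCC(NCc2ccccc2)CC1` and compound 2 `CCOC(=O)c1sc(-c2ccccn2)nc1N1CCC(NCc2cccc(C(F)(F)F)c2)CC1` share one core and differ only by a trifluoromethyl in place of hydrogen on an aromatic carbon. In an ADME assay on RAW264.7 cells (Mus musculus) for cytotoxicity, read by MTT assay, with a stated time of 72 h, tested at 50 uM (a higher number here means more inhibition at the concentration tested (going by the name of the read-out), a lower number less inhibition), compound 1 gives 14.6% and compound 2 gives 19.2%; the step of a number 4.6 percentage points higher from compound 1 to compound 2 (within the scatter) is within the scatter, so the two values cannot be ordered. Among the compounds with values here, compound 2 holds the higher of the two numbers recorded so far in this assay, with compound 1 as its only neighbour and within the scatter of it. Compound 3 `CCOC(=O)c1sc(-c2ccccn2)nc1N1CCC(NCc2ccc(Cl)cc2Cl)CC1` is the next member; compared with compound 2 the difference is 2,4-dichlorophenyl in place of 3-(trifluoromethyl)phenyl on a saturated chain carbon bound to an amine nitrogen. Within the data shown here, only the step of a number 4.6 percentage points higher from compound 1 to compound 2 (within the scatter) bears on this change, as it also altered the group on the saturated chain carbon bound to the amine nitrogen, and it stayed within the scatter; no measured step in this assay moves beyond the scatter. The expectation for compound 3 is therefore a step of about a number 0.8 percentage points higher from compound 2 to compound 3 (within the scatter) in this assay, that is, nothing beyond the scatter. Compound 3 is estimated at 20%, with a range from 5% to 40%.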

Compound 3, a percentage reported as inhibition, at one concentration (the size of the read-out at that concentration, not a potency): 18.6%
Compound 3: middle estimate off by 1.4 percentage points, on the high side; the range from low to high includes it.
By their numbers in this assay, from the lowest: compounds 1, 3 and 2 (each within the scatter of the next).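

In this assay the 2,4-dichlorophenyl group on a saturated chain carbon bound to an amine nitrogen, entering in place of 3-(trifluoromethyl)phenyl, gives a number 0.6 percentage points lower from compound 2 to compound 3 (within the scatter) and, entering in place of phenyl, gives a number 4 percentage points higher from compound 1 to compound 3 (within the scatter). Where one step at this position stood before, three aromatic groups now stand there, and swapping the chlorine-bearing ring for either the unsubstituted ring or the trifluoromethyl-bearing ring produces no step beyond the scatter, so within these compounds the change of ring substituents at this position does not separate the numbers. No other information on these compounds bears on this result, so nothing can be said about what lies behind it.

All three compounds carry a benzyl group on the amine nitrogen and share the ethyl ester, so the compounds shown leave open whether a non-aromatic group such as cyclohexylmethyl, a pyridylmethyl group or a carboxylic acid on the ring would give a step beyond the scatter. Equally open, going by these compounds, is what a carboxylic acid or an amide in place of the ethyl ester would do to the number in this assay.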